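Cyclopentyl for butyl on the core of compound 1

The source may hold more compounds than are shown below. What is called first, only, known or untested is meant among the compounds shown, and "the series" means these compounds.

Measured compounds:
compound 1, `CCCCn1cnc2c(Nc3cccc(Cl)c3)nc(NCOCc3ccc(/C=C/C(=O)Nc4ccccc4N)cc3)nc21`: 4.76%
compound 2, `CCC(C)n1cnc2c(NCc3ccc(C(=O)Nc4ccccc4N)cc3)nc(Cl)nc21`: 74.6%
compound 3, `Nc1ccccc1NC(=O)c1ccc(Cn2cnc3c(Nc4ccccc4)nc(Cl)nc32)cc1`: 71.4%

All three were run in a functional assay on HCT-116 cells (Homo sapiens) for antiproliferative activity, read by CCK-8 assay, with a stated time of 72 h, tested at 2 uM; a lower number here means a weaker effect, a higher number a stronger effect of the compound at the concentration tested. Compound 1 gives 4.76% and stands lowest of the three numbers. The nearest number is that of compound 3 with 71.4%, a gap beyond the scatter; compound 2 with 74.6% lies furthest away, also beyond the scatter. Among the compounds with values here, compounds 2 and 3 share no single-point relation with compound 1, so their values show only that the shared core can reach strong inhibition with other substitution, not what any one change is worth.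

Compound 4, `Nc1ccccc1NC(=O)/C=C/c1ccc(COCNc2nc(Nc3cccc(Cl)c3)c3ncn(C4CCCC4)c3n2)cc1`, has not yet been measured in this assay. It differs from compound 1 as follows: cyclopentyl in place of butyl on an aromatic nitrogen. Within the data shown here, no pair of measured compounds isolates such a change, so there is no measured step to lean on. With compound 1 at 4.76% the starting number is a low one, and a small swap of this kind is expected to give a step of a number 5.2 percentage points higher from compound 1 to compound 4 (within the scatter) that stays within the scatter, if anything slightly upward. Compound 4 is therefore estimated at 10%, with a range from 0% to 30%.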

Compound 4, a percentage reported as inhibition, at one concentration (the size of the read-out at that concentration, not a potency): 9.04%
Compound 4: middle estimate off by 1 percentage points, on the high side; low and high end bracket the measured number.
By their numbers in this assay, from the lowest: compounds 1 and 4 (each within the scatter of the next); then compounds 3 and 2 (each within the scatter of the next).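

In this assay, within the data shown here, cyclopentyl in place of butyl on an aromatic nitrogen gives a number 4.3 percentage points higher from compound 1 to compound 4 (within the scatter) and is the only single-place step measured at this position so far. Exchanging the open chain for a five-membered non-aromatic ring of carbon only does not lift the read-out out of the low range at this concentration: compound 1 gives 4.76% and compound 4 gives 9.04% in the same test. Nothing measured on these compounds speaks to why the step is this small.

From the compounds shown here alone, whether any group on this nitrogen can move the number in this compound frame remains open; a longer chain such as hexyl, a branched group such as isopropyl, or a chain ending in an amine or a carboxylic acid would test that. Among these compounds, also open is which part of compound 1 holds the read-out low, as no single-place step yet touches any other part of the molecule, for example the chain carrying the aminophenyl amide.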